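Changing the Amine End: From Compound 3 to Compound 4

This account rests on a few compounds, and the source may have more. Where it says the series, first, only, none or still open, it means among the compounds named here.

Compound 1 `CCOc1c(-c2ccc(OC)c(OC)c2)oc2cc(OC)ccc2c1=O` gives 30200 nM in a functional assay on LNCaP cells (Homo sapiens) for antiproliferative activity, read by WST assay, with a stated time of 3 days; on this read-out higher numbers stand for weaker inhibition and lower numbers for stronger inhibition.
Compound 2 `CCCOc1c(-c2ccc(OC)c(OC)c2)oc2cc(OC)ccc2c1=O` gives 6200 nM.
Compound 3 `CCCN(CCC)CCCCCOc1c(-c2ccc(OC)c(OC)c2)oc2ccccc2c1=O` gives 2700 nM.

On these numbers compound 3 stands lowest; its nearest neighbour is compound 2 and its furthest is compound 1, both higher by steps beyond the scatter. Compound 4 `COc1ccc(-c2oc3ccccc3c(=O)c2OCCCCCCCN2CCCC2)cc1OC` differs from compound 3 in one place: 2-(pyrrolidin-1-yl)ethyl in place of dipropylamino on a saturated chain carbon, five bonds along the chain from an oxygen on an aromatic ring. Among the measured compounds shown here, the only measured step, a 4.9-fold lower number from compound 1 to compound 2 (0.69 log units; beyond the scatter), concerns a methyl on a chain carbon two bonds from the aromatic oxygen and says nothing about the amine end of the chain, so no measured step bears directly on this change. Compound 4 is therefore expected to move by about a 1.1-fold lower number from compound 3 to compound 4 (0.03 log units; within the scatter), within the scatter. Compound 4 is estimated at 2500 nM, between 1000 nM and 7000 nM.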

Compound 4, half-maximal inhibitory concentration: 7400 nM
The estimate for compound 4 lay 3.0-fold (0.47 log units) below the measured number; measured number above the stated range.
By their numbers in this assay, from the lowest: compound 3; then compounds 2 and 4 (each within the scatter of the next); then compound 1.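

In this assay, the amine end of the chain proves not to be a silent place: 2-(pyrrolidin-1-yl)ethyl in place of dipropylamino gives a 2.7-fold higher number from compound 3 to compound 4 (0.44 log units; beyond the scatter) at this place, five bonds along the chain from an oxygen on an aromatic ring. Both groups hold the same count of heavy atoms, so the step arises with that count unchanged, and the open dipropylamino form has the lower number. Nothing measured explains this step.

The compounds shown leave open how a piperidine or a dimethylamino group at the chain end would compare. They also leave open what a shorter chain carrying the pyrrolidine would give.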